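The compounds below may be only part of what the source reports. "The series", "measured", "known", "first", "only" and "open" are said of these compounds alone.

Working notes on the series. Compound 1 `Cc1ccc(-n2cc(Cn3nc(N)c4c(C(F)(F)F)cc(-c5ccccc5)nc43)nn2)cc1` and compound 2 `Nc1nn(Cc2cn(CC(=O)Nc3cccc(F)c3)nn2)c2nc(-c3ccccc3)cc(C(F)(F)F)c12` share one core and differ only at the aromatic nitrogen that carries the side group. In a functional assay on THP-1 cells (Homo sapiens) for cytotoxicity, read by MTT assay, with a stated time of 24 h (a lower number here means a stronger inhibitor, a higher number a weaker inhibitor), compound 1 gives 98.6 ug/mL. In this assay compound 2 gives 99.5 ug/mL. Among the measured compounds shown here, compound 2 stands as the higher of the two numbers so far, yet the step from compound 1 to compound 2 is a 1.0-fold higher number from compound 1 to compound 2 (0.00 log units; within the scatter), so the two compounds are not told apart by these numbers.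

Compound 3 `Nc1nn(Cc2cn(CC(=O)Nc3ccc(F)cc3Br)nn2)c2nc(-c3ccccc3)cc(C(F)(F)F)c12` is the next member. The change from compound 2 is 2-bromo-4-fluorophenyl in place of 3-fluorophenyl on an amide-type nitrogen. For the measured compounds named here, no measured step alters the amide-borne aryl group, so the only guidance is that the much larger change from compound 1 to compound 2 left this assay unmoved. Compound 3 is therefore expected to move by a 1.0-fold lower number from compound 2 to compound 3 (0.02 log units; within the scatter), a step within the scatter. Compound 3 is estimated at 95 ug/mL, with a range from 55 ug/mL to 160 ug/mL.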

Compound 3, half-maximal inhibitory concentration: 65.6 ug/mL
Beside the measured number, compound 3's estimate is 1.4-fold (0.16 log units) above it; low and high end bracket the measured number.
By their numbers in this assay, from the lowest: compounds 3, 1 and 2 (each within the scatter of the next).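

Among the compounds shown here, compound 3 gives the first measured step at the aryl group on the amide-type nitrogen: in this assay, 2-bromo-4-fluorophenyl in place of 3-fluorophenyl gives a 1.5-fold lower number from compound 2 to compound 3 (0.18 log units; within the scatter), so this change does not tell the two compounds apart. Read against the group on the aromatic nitrogen of compound 1, the full ((2-bromo-4-fluorophenyl)carbamoyl)methyl group gives a 1.5-fold lower number from compound 1 to compound 3 (0.18 log units; within the scatter), which again does not separate the pair. Nothing measured here speaks to the reason for these numbers.

Still open, from the compounds shown here alone, is whether an amine or a carboxylic acid on that phenyl ring would give a step beyond the scatter in this assay. Going by these compounds, the trifluoromethyl and phenyl groups on the shared core are the same in all three compounds, so the effect of a methyl or a hydrogen in their place also remains unknown.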